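The compounds below may be only part of what the source reports. "The series", "measured", "known", "first", "only" and "open" are said of these compounds alone.

Measured in a functional assay on HL-60 cells (Homo sapiens) for cytotoxicity, read by colorimetric assay and neutral red uptake, with a stated time of 72 h; a lower number here means a stronger inhibitor, a higher number a weaker inhibitor:
- compound 1 `CO[C@@H](C(=O)N[C@H]1CCCCNC1=O)[C@H](O)[C@@H](O)[C@H](O)/C=C/C(C)(C)C`: 83300 nM
- compound 2 `CO[C@@H](C(=O)N[C@H]1CC[C@@H](O)CNC1=O)[C@H](O)[C@@H](O)[C@H](O)/C=C/C(C)(C)C`: > 150000 nM

Compound 2 gives > 150000 nM, which is a limit of the assay and not a number. Its standing is therefore known only as the limit of > 150000 nM in this assay, at which 1 of the 2 values shown sits.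

Compound 3 `CO[C@@H](C(=O)N[C@@H]1CCCCNC1=O)[C@H](O)[C@@H](O)[C@H](O)/C=C/C(C)(C)C` is reached through (2-oxoazepan-3-yl in place of 6-hydroxy-2-oxoazepan-3-yl on an amide-type nitrogen), with 2-oxoazepan-3-yl in place of 6-hydroxy-2-oxoazepan-3-yl on an amide-type nitrogen. Among the measured compounds shown here, the one measured step bearing on this is an at least 1.8-fold higher number from compound 1 to compound 2 (0.25 log units; that floor lies within the scatter), where hydroxy replaces hydrogen on a saturated ring carbon. From the compounds shown here alone, the floor of that step lies within the scatter, and its true size is unknown. Compound 3 loses that hydroxy, so a modest move toward a lower number is expected in this assay, though possibly none beyond the scatter. The expected change is an at least 1.5-fold lower number from compound 2 to compound 3 (0.17 log units; that floor lies within the scatter). With a single step to go on, the range stays wide. For compound 3 the estimate is 100000 nM, with an expected range of 40000 nM to 230000 nM.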

Compound 3, half-maximal inhibitory concentration: 5300 nM
Beside the measured number, compound 3's estimate is 19-fold (1.28 log units) above it, and the stated range ends above it.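

Inverting the stereocentre at a saturated ring carbon, from S to R, gives a 16-fold lower number from compound 1 to compound 3 (1.20 log units; beyond the scatter) in this assay. This gap is traced to configuration alone, because nothing else separates the pair: the fact that compounds 1 and 3 differ only in the configuration as drawn

The replacement of 6-hydroxy-2-oxoazepan-3-yl by 2-oxoazepan-3-yl on the amide-type nitrogen gives an at least 28-fold lower number from compound 2 to compound 3 (1.45 log units; beyond the scatter); this size is only a floor, since the reading for compound 2 is a limit, and the step carries the same inversion, so it does not isolate loss of the hydroxy.

From the compounds shown here alone, the effect of the hydroxy on the R form remains open, since that group has been read only on the S form. Also open, going by these compounds, is whether an amine or a carboxylic acid on the ring of the R form would keep the lower number seen for compound 3.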